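Methylsulfonyl in place of isobutyl on the shared core

This account rests on a few compounds, and the source may have more. Where it says the series, first, only, none or still open, it means among the compounds named here.

Values in a functional assay on HCT-8 cells (Homo sapiens) for cytotoxicity; on this read-out lower numbers stand for an effect already at smaller amounts and higher numbers for an effect only at larger amounts of compound:
- Compound 1 `CCOc1cc(-c2ccccc2)nc2ccccc12`: > 10 ug/mL (a limit)
- Compound 2 `c1ccc(COc2cc(-c3ccccc3)nc3ccccc23)cc1`: > 10 ug/mL (a limit)
- Compound 3 `CC(C)COc1cc(-c2ccccc2)nc2ccccc12`: > 10 ug/mL (a limit)
- Compound 4 `CS(=O)(=O)Oc1cc(-c2ccccc2)nc2ccccc12`: not yet measured

Compound 3 has no number, only the limit > 10 ug/mL. The other two compounds also stand at a limit, as the limit of > 10 ug/mL in this assay, at which 3 of the 3 values shown sit, records.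

The next change puts methylsulfonyl in place of isobutyl on an oxygen on an aromatic ring.

Among the compounds with values here, three measured steps bear on it, all on a saturated chain carbon bound to that oxygen: a step that the two limits leave unreadable from compound 1 to compound 2, a step that the two limits leave unreadable from compound 1 to compound 3 and a step that the two limits leave unreadable from compound 2 to compound 3. None has a readable size, and none introduces methylsulfonyl. No step size can therefore be carried over, and no shift in a known direction is expected in this assay.

The expected result is a step that the limit leaves unreadable from compound 3 to compound 4, and another limit is the likeliest report. For compound 4 the estimate is 12 ug/mL, within an expected range of 4 ug/mL to 30 ug/mL.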

Compound 4, half-maximal effective concentration: 5.6 ug/mL
For compound 4 the middle estimate is 2.1-fold (0.33 log units) above the measured one; measured number inside the range.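

In this assay compound 4 is the only one of the series with a number, while the others stay at a limit: the limit of > 10 ug/mL in this assay, at which 3 of the 4 values shown sit.

In place of isobutyl, methylsulfonyl gives an at least 1.7-fold lower number from compound 3 to compound 4 (0.25 log units; that floor lies within the scatter) on this oxygen, in place of benzyl it gives an at least 1.7-fold lower number from compound 2 to compound 4 (0.25 log units; that floor lies within the scatter) and in place of ethyl it gives an at least 1.7-fold lower number from compound 1 to compound 4 (0.25 log units; that floor lies within the scatter) on the same oxygen, so each step is bounded on one side only and its floor does not clear the scatter. Within the data shown here, the steps among compound 1, compound 2 and compound 3 cannot be read, which leaves methylsulfonyl as the only change here that brings this position into the readable range.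

As far as these compounds go, whether that value is specific to methylsulfonyl stays open, as phenylsulfonyl or acetyl on the same oxygen would be needed to tell. From the compounds shown here alone, how a chain ending in an amine or a carboxylic acid would read at this position is also open.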